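This account rests on a few compounds, and the source may have more. Where it says the series, first, only, none or still open, it means among the compounds named here.

Measured in a functional assay on Jurkat cells (Homo sapiens) for antiproliferative activity, read by MTT assay, with a stated time of 72 h; a lower number here means a stronger inhibitor, a higher number a weaker inhibitor:
Compound 1 `CCOc1ccc(-c2sc(N(C)C)nc2-c2cc(OC)c(OC)c(OC)c2)cc1`: 4150 nM
Compound 2 `COc1cc(-c2nc(C)sc2-c2ccc(C(F)(F)F)cc2)cc(OC)c1OC`: 7110 nM

Going by the values given here, these are the only two measurements available. Compound 2, at 7110 nM, lies within the usual scatter of compound 1, so the numbers set no order between them. Both compounds sit in the micromolar range, and neither can be called the better inhibitor.

Compound 3 `CCOc1ccc(-c2sc(C)nc2-c2cc(OC)c(OC)c(OC)c2)cc1` departs from compound 2 in one place: ethoxy in place of trifluoromethyl on an aromatic carbon.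

Among the compounds with values here, no two measured compounds differ in just one place, so no measured step shows how large this change might be. Within the data shown here, the one measured compound with ethoxy is compound 1, at 4150 nM, and that value offers only weak guidance. A moderate step towards a lower number in this assay is expected, but with wide uncertainty, and a step within the scatter would be no surprise. The expected change is a 4.7-fold lower number from compound 2 to compound 3 (0.68 log units; beyond the scatter). For compound 3 the estimated value is 1500 nM, with an expected range from 200 nM to 8000 nM.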

Compound 3, half-maximal inhibitory concentration: 1740 nM
Compound 3: the middle estimate sits 1.2-fold (0.06 log units) below what was measured; the measured number falls inside the stated range.
By their numbers in this assay, from the lowest: compound 3; then compounds 1 and 2 (each within the scatter of the next).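

In this assay, the change at this aromatic carbon, para to a large group, now has a measured size: ethoxy in place of trifluoromethyl gives a 4.1-fold lower number from compound 2 to compound 3 (0.61 log units; beyond the scatter). Going by these compounds alone, the position therefore responds to its substituent, although a pair of groups gives only a modest step, and the earlier compounds could not show this because they differed in more than one place. With ethoxy held constant, a second place on the shared core also matters, since methyl in place of dimethylamino on an aromatic carbon gives a 2.4-fold lower number from compound 1 to compound 3 (0.38 log units; beyond the scatter), while nothing available here explains why either change acts as it does.

As far as these compounds go, only trifluoromethyl and ethoxy can be compared at the first position, so it remains open whether methoxy, a longer chain such as propoxy, or an amine there would lower the number further or raise it. At the second place, the comparison covers only methyl and dimethylamino, leaving open how a primary amine or a longer chain such as ethyl would fit into this short series.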